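This account rests on a few compounds, and the source may have more. Where it says the series, first, only, none or still open, it means among the compounds named here.

Compound 1 `C#CCOc1cc(/C=C/C(=O)c2ccc(OC)c3c2OC(C)(C)C=C3)ccc1OC`, compound 2 `COc1ccc(/C=C/C(=O)c2ccc(OC)c3c2OC(C)(C)C=C3)cc1OCCO` and compound 3 `C=CC(=O)Oc1cc(/C=C/C(=O)c2ccc(OC)c3c2OC(C)(C)C=C3)ccc1OC` share one core and differ only in the group carried on an oxygen on an aromatic ring. In an ADME assay on L02 cells (Homo sapiens) for cytotoxicity, read by MTT assay (on this read-out lower numbers stand for stronger inhibition and higher numbers for weaker inhibition), compound 1 gives a limit, > 10000 nM. Compound 2 also gives only a limit, > 10000 nM. Compound 3 likewise gives only a limit, > 10000 nM. None of the three is a number; all three sit at the limit of > 10000 nM in this assay, at which 3 of the 3 values shown sit. The steps a step that the two limits leave unreadable from compound 1 to compound 2, a step that the two limits leave unreadable from compound 1 to compound 3 and a step that the two limits leave unreadable from compound 2 to compound 3 are therefore unreadable. Compound 3 thus stands at the limit, with nothing to separate it from compound 1 or compound 2.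

Compound 4 `COc1ccc(/C=C/C(=O)c2ccc(OC)c3c2OC(C)(C)C=C3)cc1OC(=O)c1ccco1` follows from compound 3 by a single change: furan-2-yl in place of vinyl on a carbonyl carbon. Cut one bond further out, the vinylcarbonyl becomes (furan-2-yl)carbonyl. The three measured steps all sit on this same oxygen, yet none has a readable size, so no measured step sizes this change; the only anchor is the limit of > 10000 nM in this assay, at which 3 of the 3 values shown sit. The expectation for compound 4 is a step that the limit leaves unreadable from compound 3 to compound 4, most likely again reported as a limit. Compound 4 is estimated at 15000 nM, within 5000 nM to 50000 nM.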

Compound 4, half-maximal inhibitory concentration: > 10000 nM
Compound 4 gave a limit, no number; the forecaster's own chance of this, stated with the estimate: 85%; the middle value does not contradict the limit.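

The steps to compound 4 from compound 1, compound 2 and compound 3 cannot be read, and all four compounds give only a limit: the limit of > 10000 nM in this assay, at which 4 of the 4 values shown sit.

The compounds shown leave open whether any group on this oxygen on an aromatic ring separates one compound from another in this assay.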